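Chloro for 4-methoxyphenyl on the benzoxazolone carbamate core

The source may report more compounds than this note shows. Statements on the series, on what has been measured and on what is new or still open speak of the compounds shown alone.

Going by the values given here, compound 2 `COc1ccc(-c2ccc3c(c2)oc(=O)n3C(=O)NCCCCc2ccccc2)cc1` gives 67 nM in an assay on HEK293 cells for inhibition of acid ceramidase (Homo sapiens), with a stated time of 10 min (a higher number here means a weaker inhibitor, a lower number a stronger inhibitor), and stands as the higher of the two numbers measured so far. Among the compounds with values here, its nearest neighbour, compound 1 `O=C(c1ccccc1)c1ccc2c(c1)oc(=O)n2C(=O)NCCCCc1ccccc1`, gives 29 nM in this assay, and the only measured step, a 2.3-fold higher number from compound 1 to compound 2 (0.36 log units; beyond the scatter), lies beyond the scatter but is modest. Compound 3 `O=C(NCCCCc1ccccc1)n1c(=O)oc2cc(Cl)ccc21` differs from compound 2 by chloro in place of 4-methoxyphenyl on an aromatic carbon, so a larger group is replaced by a small one at the same place. Within the data shown here, no measured step bears directly on this exchange; the benzoyl-to-4-methoxyphenyl step only shows that two different large groups at this place give numbers within a modest span. The change to compound 3 is therefore expected to stay within a modest range, with no firm direction, giving an estimated 1.1-fold lower number from compound 2 to compound 3 (0.05 log units; within the scatter). Compound 3 is expected to show about 60 nM, within a range from 15 nM to 250 nM.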

Compound 3, half-maximal inhibitory concentration: 33 nM
The estimate for compound 3 lay 1.8-fold (0.26 log units) above the measured number; low and high end bracket the measured number.
By their numbers in this assay, from the lowest: compounds 1 and 3 (each within the scatter of the next); then compound 2.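

Exchanging 4-methoxyphenyl for chloro at this aromatic carbon gives a 2.0-fold lower number from compound 2 to compound 3 (0.31 log units; beyond the scatter) and shows that the place does not need a large group with its own ring to keep a low number. Exchanging benzoyl for chloro at the same carbon gives a 1.1-fold higher number from compound 1 to compound 3 (0.06 log units; within the scatter) and so leaves those two groups indistinguishable here, which means that group size alone does not order the three compounds: only 4-methoxyphenyl stands apart, while large benzoyl and small chloro sit together. Nothing shown accounts for this difference.

The compounds leave open whether other small groups at this place, such as fluoro or methyl, would match chloro. They also leave open how an amine or a carboxylic acid would fare there, and whether chloro would hold its number with a shorter chain on the amide nitrogen.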